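A Second Ethyl on the Nitrogen

This account rests on a few compounds, and the source may have more. Where it says the series, first, only, none or still open, it means among the compounds named here.

compound 1 `Nc1cc2nc(-c3ccccc3)nn(-c3ccccc3)c-2cc1=O`: 1830 nM
compound 2 `CCNc1cc2nc(-c3ccccc3)nn(-c3ccccc3)c-2cc1=O`: 220 nM

In a functional assay on DU-145 cells (Homo sapiens) for cytotoxicity, read by MTT assay, with a stated time of 72 h (a lower number here means a stronger inhibitor, a higher number a weaker inhibitor), compound 2 has the lower of the two measured numbers, 220 nM. Compound 3 `CCN(CC)c1cc2nc(-c3ccccc3)nn(-c3ccccc3)c-2cc1=O` differs from it by one change: ethyl in place of hydrogen on a nitrogen on an aromatic ring, which takes ethylamino to diethylamino. For the measured compounds named here, only one measured step bears on this, the same kind of swap: an 8.3-fold lower number from compound 1 to compound 2 (0.92 log units; beyond the scatter), which is beyond the scatter. One step is thin evidence, and a second ethyl need not repeat it, so a smaller step towards a lower number is expected in this assay. The estimated step is a 1.5-fold lower number from compound 2 to compound 3 (0.17 log units; within the scatter). For compound 3 the expected value is 150 nM, with an estimated range of 45 nM to 500 nM.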

Compound 3, half-maximal inhibitory concentration: 3110 nM
The estimate for compound 3 lay 21-fold (1.32 log units) below the measured number; measured number above the stated range.
By their numbers in this assay, from the lowest: compound 2; then compounds 1 and 3 (each within the scatter of the next).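

In this assay the same swap on this nitrogen does not act the same way twice: the second ethyl gives a 14-fold higher number from compound 2 to compound 3 (1.15 log units; beyond the scatter) and so undoes the drop seen with the first. Diethylamino and amino differ by only a 1.7-fold higher number from compound 1 to compound 3 (0.23 log units; within the scatter) and so sit level, which means the low number here belongs to ethylamino alone among these three groups. No measurement shown explains this reversal. Still open, on these data alone, is whether methylamino or propylamino would keep the low number, or whether it is specific to ethyl.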